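Shortening a Side Chain from 2-Methoxyethyl to Ethyl

The compounds below may be only part of what the source reports. "The series", "measured", "known", "first", "only" and "open" are said of these compounds alone.

Among the compounds with values here, compound 2 `COCCNc1nnc(SCC(=O)N(Cc2cccc([N+](=O)[O-])c2)c2ccc(F)cc2)s1` gives 38.6% in an assay on isolated protein for inhibition of Amine oxidase [flavin-containing] B (Homo sapiens), read by fluorescence and Amplex Red, with a stated time of 30 min, tested at 1 mM (on this read-out lower numbers stand for a weaker effect and higher numbers for a stronger effect at the one concentration tested), and the only other measured compound, compound 1 `CCCNc1nnc(SCC(=O)N(Cc2cccc([N+](=O)[O-])c2)c2ccc(F)cc2)s1`, gives 42.7%, a number within the scatter of it. Within the data shown here, the single measured step, a number 4.1 percentage points lower from compound 1 to compound 2 (within the scatter), altered the same chain and stayed within the scatter. Compound 3 `CCNc1nnc(SCC(=O)N(Cc2cccc([N+](=O)[O-])c2)c2ccc(F)cc2)s1` has not yet been measured; it differs from compound 2 by hydrogen in place of methoxy on a saturated chain carbon, two bonds along the chain from a nitrogen on an aromatic ring. Among the measured compounds shown here, because the one comparable step, a number 4.1 percentage points lower from compound 1 to compound 2 (within the scatter), was within the scatter, no step beyond the scatter is expected for a number 2.4 percentage points higher from compound 2 to compound 3 (within the scatter). Compound 3 is therefore estimated at 41%, between 30% and 52%.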

Compound 3, a percentage reported as inhibition, at one concentration (the size of the read-out at that concentration, not a potency): 41.3%
Compound 3: middle estimate off by 0.3 percentage points, on the low side; the range from low to high includes it.
By their numbers in this assay, from the lowest: compounds 2, 3 and 1 (each within the scatter of the next).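

In this assay, hydrogen in place of methoxy gives a number 2.7 percentage points higher from compound 2 to compound 3 (within the scatter) and hydrogen in place of methyl gives a number 1.4 percentage points lower from compound 1 to compound 3 (within the scatter). So across these three compounds, the chain carbon at this position carries hydrogen, methyl or methoxy with no step beyond the scatter, and shortening to ethylamino is no exception. No outside evidence bears on this result. Still open, from the compounds shown here alone, is whether an amine or a carboxylic acid on this chain, or a much longer chain, would give a step beyond the scatter.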